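A few compounds are considered here, and "the series" means these few. Any claim that something is new, unique, unknown or untested is made for them only; others in the source may bear on it.

Compounds 1, 2 and 3 share one core and differ only in the group on a saturated chain carbon bound to a nitrogen on an aromatic ring. In a functional assay on HL-60 cells (Homo sapiens) for antiproliferative activity, with a stated time of 72 h (on this read-out lower numbers stand for stronger inhibition and higher numbers for weaker inhibition), compound 1 `OC[C@H]1O[C@@H](n2cnc3c(NCc4ccccc4F)ncnc32)[C@H](O)[C@@H]1O` gives 3200 nM. In this assay, compound 2 `OC[C@H]1O[C@@H](n2cnc3c(NCc4ccc(F)cc4)ncnc32)[C@H](O)[C@@H]1O` gives 1200 nM, and the measured change is a 2.7-fold lower number from compound 1 to compound 2 (0.43 log units; beyond the scatter).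

Compound 3 `Cc1ccc(CNc2ncnc3c2ncn3[C@@H]2O[C@H](CO)[C@@H](O)[C@H]2O)cc1` gives only a limit, > 166000 nM, and no number; this is the limit of > 166000 nM in this assay, at which 1 of the 3 values shown sits. The measured changes leading to it are far larger: an at least 51-fold higher number from compound 1 to compound 3 (1.71 log units; beyond the scatter) and an at least 130-fold higher number from compound 2 to compound 3 (2.14 log units; beyond the scatter).

Compound 4 `COc1ccc(CNc2ncnc3c2ncn3[C@@H]2O[C@H](CO)[C@@H](O)[C@H]2O)c(OC)c1` keeps the core but carries a new group: 2,4-dimethoxyphenyl in place of 4-methylphenyl on a saturated chain carbon bound to a nitrogen on an aromatic ring. Going by the values given here, no measured compound has this 2,4-dimethoxyphenyl group, so the earlier steps guide the size of the change only loosely. They do show that changing this group alone can move the number a long way, as in an at least 130-fold higher number from compound 2 to compound 3 (2.14 log units; beyond the scatter). A sizeable drop from the limit is therefore expected, though compound 4 may also remain at the limit. The expected change is an at least 5.5-fold lower number from compound 3 to compound 4 (0.74 log units; beyond the scatter). For compound 4, the estimated value is 30000 nM, with an expected range from 3000 nM to 166000 nM.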

Compound 4, half-maximal inhibitory concentration: 39000 nM
Compound 4: middle estimate off by 1.3-fold (0.11 log units), on the low side; the range from low to high includes it.
By their numbers in this assay, from the lowest: compound 2; then compound 1; then compound 4. At a limit, above all of these: compound 3.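

In this assay, swapping the group on a saturated chain carbon bound to a nitrogen on an aromatic ring brings compound 4 back to a measured number, with an at least 4.2-fold lower number from compound 3 to compound 4 (0.62 log units; beyond the scatter). Compound 3 has only a limit and no number, so that step sets a minimum size: the limit of > 166000 nM in this assay, at which 1 of the 4 values shown sits. The recovery is only partial, since 2,4-dimethoxyphenyl still falls well short of both fluorinated groups, with a 33-fold higher number from compound 2 to compound 4 (1.51 log units; beyond the scatter) and a 12-fold higher number from compound 1 to compound 4 (1.09 log units; beyond the scatter).

The new group has two methoxy groups, so these compounds cannot show whether one of them alone accounts for the change. From the compounds shown here alone, how a 2-methoxyphenyl, a 4-methoxyphenyl or a 4-chlorophenyl group would compare at this position remains open, as does whether any group here can give a lower number than compound 2, which gives 1200 nM.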